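A few compounds are considered here, and "the series" means these few. Any claim that something is new, unique, unknown or untested is made for them only; others in the source may bear on it.

Compound 1, whose structure is `CCCCCNc1cnc(C(=O)NCc2ccccc2)cn1`, compound 2, whose structure is `CCCCCCCNc1cnc(C(=O)NCc2ccccc2)cn1`, and compound 3, whose structure is `CCCCCCCNc1cncc(C(=O)NCc2ccccc2)n1`, were examined in an ADME assay on Vero cells (Chlorocebus sabaeus) for cytotoxicity, read by microscopy, with a stated time of 6 days; on this read-out lower numbers stand for higher toxicity in this test and higher numbers for lower toxicity in this test. The readings give only limits of the test rather than numbers. In this assay compound 1 gives > 100000 nM, which is a limit of the assay. In this assay compound 2 gives >= 100000 nM, a limit as well. In this assay compound 3 gives > 100000 nM, again a limit.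

Compound 2 and compound 1 differ by hydrogen in place of ethyl on a saturated chain carbon, five bonds along the chain from a nitrogen on an aromatic ring. The step that the two limits leave unreadable from compound 2 to compound 1 cannot be sized because the limit of > 100000 nM in this assay, at which 2 of the 3 values shown sit, and the limit of >= 100000 nM in this assay, at which 1 of the 3 values shown sits, together mark where both readings stop. Compound 2 and compound 3 share the same atoms joined differently; the difference between their two cores is not broken down here.

Compound 4, whose structure is `CCCCCNc1cncc(C(=O)NCc2ccccc2)n1`, has not yet been measured in this assay. It differs from compound 3 by hydrogen in place of ethyl on a saturated chain carbon, five bonds along the chain from a nitrogen on an aromatic ring, the same change that separates compound 2 from compound 1, here carried out on the core of compound 3. The step expected from compound 3 to compound 4 is a number no higher from compound 3 to compound 4 (the limit leaves the size open), an expectation resting on the pair of compound 2 and compound 1, where the change left both readings at the limit. Compound 4 is therefore expected to give about 100000 nM in this assay, within a range from 50000 nM to 200000 nM, most likely reported as a limit again.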

Compound 4, minimum cytotoxic concentration: > 100000 nM
Compound 4: no number, only a limit; the forecaster's own chance of this, stated with the estimate: 85%; the middle value sits exactly at the limit.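

In this assay compound 4 gives > 100000 nM, again a limit and not a number. No step can be read between compound 3 and compound 4, because both readings stop at the same limit: the limit of > 100000 nM in this assay, at which 3 of the 4 values shown sit.

The compounds shown leave open where any of the four would begin to show toxicity in this assay, and so whether the chain or the core makes any difference there.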